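The compounds below may be only part of what the source reports. "The series", "measured", "known", "first", "only" and "open" are said of these compounds alone.

Measured so far:
compound 1, `CC(Sc1nc2c(cnn2C)c(=O)n1-c1ccc(CCO)cc1)c1ccccc1` — 216 nM
compound 2, `Cn1ncc2c(=O)n(-c3ccccc3)c(SC(C)(C)c3ccccc3)nc21` — 2200 nM
compound 3, `C[C@@H](Sc1nc2c(cnn2C)c(=O)n1-c1ccccc1)c1ccccc1` — 40 nM

In an assay on isolated protein for inhibition of retinal dehydrogenase 2 (Homo sapiens) (on this read-out higher numbers stand for weaker inhibition and lower numbers for stronger inhibition), compound 3 gives the lowest number of the three, with both of its gaps to the others beyond the scatter, so on these numbers it is the strongest inhibitor of the set. Among the measured compounds shown here, the one step that changes the group on the sulfur is a 55-fold lower number from compound 2 to compound 3 (1.74 log units; beyond the scatter), a large gain when the branching at the carbon attached to sulfur is reduced.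

Compound 4, `CC(Sc1nc2c(cnn2C)c(=O)n1-c1ccccc1)c1ccccn1`, keeps that carbon and its substitution pattern and differs from compound 3 only by 1-(pyridin-2-yl)ethyl in place of 1-phenylethyl on a sulfur. For the measured compounds named here, no measured pair exchanges a ring atom in this group, so the step from compound 2 to compound 3 bears on it only in showing that this position tolerates change without loss when the branching is kept. The expectation is therefore a step no larger than the scatter, in either direction, and for compound 4 the step of a 1.8-fold higher number from compound 3 to compound 4 (0.24 log units; within the scatter) is estimated with the number 70 nM, in the range 20 nM to 250 nM.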

Compound 4, half-maximal inhibitory concentration: 63 nM
For compound 4 the middle estimate is 1.1-fold (0.05 log units) above the measured one; the range from low to high includes it.
By their numbers in this assay, from the lowest: compounds 3 and 4 (each within the scatter of the next); then compound 1; then compound 2.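

On the sulfur, a ring carbon of 1-phenylethyl can be exchanged for a ring nitrogen with no change beyond the scatter in this assay, at a 1.6-fold higher number from compound 3 to compound 4 (0.20 log units; within the scatter), even though the entering 1-(pyridin-2-yl)ethyl adds one hydrogen-bond acceptor and compound 4 has no defined stereocentre, unlike compound 3. The large step away from 1-methyl-1-phenylethyl also holds with this pyridine ring, at a 35-fold lower number from compound 2 to compound 4 (1.54 log units; beyond the scatter), so that step is now seen with two different rings.

Still open, on these data alone, is how 1-(pyridin-3-yl)ethyl or 1-(pyridin-4-yl)ethyl would read, and whether an amine or a carboxylic acid on this ring would be accepted. Also open, as far as these compounds go, is how each single stereoisomer of compound 4 would compare with compound 3. No supporting data bear on the reason for this result.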